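Moving a methoxy group around a thiosemicarbazone aryl ring

A few compounds are considered here, and "the series" means these few. Any claim that something is new, unique, unknown or untested is made for them only; others in the source may bear on it.

Of the compounds shown here, three sharing a thiosemicarbazone motif have been tested in a functional assay on HT-29 cells (Homo sapiens) for antiproliferative activity, read by sulforhodamine B assay, with a stated time of 72 h; a higher number here means a weaker inhibitor, a lower number a stronger inhibitor. Compound 1, with structure `NC(=S)N/N=C/c1cc2cccnc2s1`, gives only a limit of the assay, > 100000 nM, so no number is known for it; this is the limit (the limit of > 100000 nM in this assay, at which 1 of the 3 values shown sits). Compound 2, with structure `COc1cccc(NC(=S)N/N=C/c2ccc3ccccc3n2)c1`, gives 82400 nM in this assay. Compound 3, with structure `CN(C)C(=S)N/N=C/c1nc2ccccc2s1`, gives 250 nM. Among the two measured numbers, compound 2 stands highest, its nearest neighbour being compound 3 at a much lower number, a gap well beyond the scatter of repeat measurements.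

Compound 4, with structure `COc1ccc(NC(=S)N/N=C/c2ccc3ccccc3n2)cc1`, has not yet been measured. It is built from the same atoms as compound 2, joined differently: 4-methoxyphenyl in place of 3-methoxyphenyl on an amide-type nitrogen. Because compound 2 gives 82400 nM, and the change is only a shift of one substituent around an aromatic ring, no large step is expected; the step from compound 2 to compound 4 is expected to be a 1.0-fold lower number from compound 2 to compound 4 (0.01 log units; within the scatter), which is within the usual scatter. Compound 4 is therefore estimated at 80000 nM, with a plausible range from 30000 nM to 200000 nM.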

Compound 4, half-maximal inhibitory concentration: 82300 nM
Beside the measured number, compound 4's estimate is 1.0-fold (0.01 log units) below it; the range from low to high includes it.
By their numbers in this assay, from the lowest: compound 3; then compounds 4 and 2 (each within the scatter of the next). At a limit, above all of these: compound 1.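

Placing 4-methoxyphenyl instead of 3-methoxyphenyl on the amide-type nitrogen gives the first one-place comparison in this set, and in this assay it amounts to a 1.0-fold lower number from compound 2 to compound 4 (0.00 log units; within the scatter) on the scale of this read-out. For this pair, then, moving the methoxy group around the ring leaves the reading unchanged within the scatter, with compound 2 at 82400 nM and compound 4 at 82300 nM in the same assay, so this one shift on its own does not separate the two compounds. Nothing measured for these compounds explains why the two arrangements read alike.

As far as these compounds go, whether the ring tolerates other groups in the same way remains open, since a single methoxy group at two places says little about how an amine, a carboxylic acid or a longer alkoxy chain on that ring would read in this assay. Compound 2 and compound 4 also differ from compound 3 in more than one place, so nothing here ties the value of 250 nM for compound 3 to any single structural feature.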